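Spiro-piperidine amides at a cholesterol transporter: ester to carbamate

This account rests on a few compounds, and the source may have more. Where it says the series, first, only, none or still open, it means among the compounds named here.

The series shares one spiro core carrying a phenyl group and a para-substituted benzoyl amide on the outer piperidine, and differs in the amide attached through a short chain to the inner nitrogen. Compound 3 `CCOC(=O)C1CCN(C(=O)CN2CN(c3ccccc3)C3(CCN(C(=O)c4ccc(C5CCCCC5)cc4)CC3)C2=O)CC1` gives 900 nM in an assay on HEK293 cells for displacement of a labelled ligand from NPC1-like intracellular cholesterol transporter 1 (Homo sapiens); a lower number here means a stronger inhibitor, a higher number a weaker inhibitor. Compound 1 `CC(C)(C)c1ccc(C(=O)N2CCC3(CC2)C(=O)N(CC(=O)N2CCC(CCO)CC2)CN3c2ccccc2)cc1` gives 2600 nM in this assay. Compound 2 `CCc1nn(CC)c(C2CCN(C(=O)CN3CN(c4ccccc4)C4(CCN(C(=O)c5ccc(C6CCCCC6)cc5)CC4)C3=O)CC2)c1C` was included, but its entry in this assay reads "not determined" (no result reported), so no result was reported for it. Of the two numbers available, compound 3 holds the lower one, and the gap to compound 1 lies beyond the usual scatter, so compound 3 stands as the stronger of the two measured compounds.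

Compound 4 `CC(C)(C)OC(=O)NCCNC(=O)CN1CN(c2ccccc2)C2(CCN(C(=O)c3ccc(C4CCCCC4)cc3)CC2)C1=O` is the next compound to be examined. It differs from compound 3 in one place: (2-((tert-butoxycarbonyl)amino)ethyl)amino in place of 4-(ethoxycarbonyl)piperidin-1-yl on a carbonyl carbon. For the measured compounds named here, no pair of measured compounds shows this kind of change, so there is no measured step on which to lean; the two measured compounds differ in the benzoyl substituent as well as in the amide, which gives no clean comparison.

The step from compound 3 to compound 4 is expected to be a modest weakening, a 1.8-fold higher number from compound 3 to compound 4 (0.25 log units; within the scatter), close to the edge of the scatter. Compound 4 is therefore expected to give about 1600 nM in this assay, within a range of 500 nM to 5000 nM.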

Compound 4, half-maximal inhibitory concentration: 5500 nM
The estimate for compound 4 lay 3.4-fold (0.54 log units) below the measured number, and the stated range ends below it.
By their numbers in this assay, from the lowest: compound 3; then compound 1; then compound 4.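

Placing (2-((tert-butoxycarbonyl)amino)ethyl)amino in place of 4-(ethoxycarbonyl)piperidin-1-yl on this carbonyl carbon gives a 6.1-fold higher number from compound 3 to compound 4 (0.79 log units; beyond the scatter) in this assay, the first reading of a change made at this position alone. Both groups have 11 heavy atoms and 2 hydrogen-bond acceptors, yet the change replaces a six-membered non-aromatic ring and 0 hydrogen-bond donors with no ring and 2 hydrogen-bond donors, so a change that leaves the heavy-atom count the same can still move the number beyond the scatter. The result does not show which of these differences matters, and no measurement shown here explains the step.

The compounds shown leave open whether the tert-butoxycarbonyl group, the open chain or the loss of the ring accounts for the weaker number, and a free amine on the same chain or a carboxylic acid in place of the ethyl ester could help to separate these. Compound 1 also differs in its benzoyl substituent, so its hydroxyethyl-bearing amide cannot yet be set against either group at this position.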